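A few compounds are considered here, and "the series" means these few. Any claim that something is new, unique, unknown or untested is made for them only; others in the source may bear on it.

Compound 2 `COc1cc(/C=C/C(=O)c2cccc(-n3cc(-c4ccccc4)[nH]c3=O)c2)ccc1O` gives 2270 nM in a functional assay on RXF 393 cells (Homo sapiens) for inhibition (on this read-out higher numbers stand for weaker inhibition of growth and lower numbers for stronger inhibition of growth), a number that sits within the usual scatter of both compound 1 `COc1cc(/C=C/C(=O)c2cccc(-n3cc(-c4ccc(Cl)cc4)[nH]c3=O)c2)cc(OC)c1OC` at 3220 nM and compound 3 `COc1ccc(-c2cn(-c3cccc(C(=O)/C=C/c4cc(OC)c(OC)c(OC)c4)c3)c(=O)[nH]2)cc1` at 1920 nM. Compound 4 `COc1cc(/C=C/C(=O)c2cccc(-n3cc(-c4ccc(Cl)cc4)[nH]c3=O)c2)ccc1O` differs from compound 2 by chloro in place of hydrogen on an aromatic carbon. Going by the values given here, no measured step swaps exactly hydrogen for chloro. The closest guide is the step from compound 1 to compound 3, a 1.7-fold lower number from compound 1 to compound 3 (0.22 log units; within the scatter), which shows that changing the group at this position hardly moves the number. Since chloro already appears in compound 1 without setting it apart, compound 4 is expected to land close to compound 2, with a step of a 1.1-fold higher number from compound 2 to compound 4 (0.04 log units; within the scatter). The estimate for compound 4 is 2500 nM, spanning 1200 nM to 5200 nM.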

Compound 4, concentration for 50% growth inhibition: 6400 nM
Compound 4: middle estimate off by 2.6-fold (0.41 log units), on the low side; the measured number lies above the stated range.
By their numbers in this assay, from the lowest: compounds 3, 2, 1 and 4 (each within the scatter of the next, the first and the last beyond it).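

Going by these compounds alone, putting chloro in place of hydrogen gives a 2.8-fold higher number from compound 2 to compound 4 (0.45 log units; beyond the scatter) in this assay, the first step at this position that lies beyond the scatter, so growth inhibition here does respond to a change on this ring. The earlier step, methoxy for chloro, stayed within the scatter and could not show this. Nothing available explains why the number rises. Still open, going by these compounds, is whether an amine or a fluoro at this spot, para to a large group, would also weaken inhibition. Also open, on these data alone, is whether the hydrogen-to-chloro swap has the same size on the core of compound 1.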